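The source may report more compounds than this note shows. Statements on the series, on what has been measured and on what is new or still open speak of the compounds shown alone.

In an assay on isolated protein for binding affinity to corticotropin-releasing factor receptor 1 (Homo sapiens) (on this read-out higher numbers stand for weaker inhibition and lower numbers for stronger inhibition), the measured compounds stand as follows:
compound 1 `C=Cc1ccccc1C(Nc1ccc(C)cc1Cl)C(=O)CCc1ccncc1` gives 752 nM; 752 nM (2 entries).
compound 2 `Cc1ccc(NC(C(=O)CCc2ccncc2)c2ccccc2C(C)C)c(Cl)c1` gives 3300 nM.
compound 3 `Cc1cccc(C(Nc2ccc(C)cc2Cl)C(=O)CCc2ccncc2)c1` gives only a limit of the assay, > 10000 nM.

Compound 3 therefore stands not at a number but at a limit; its entry is the limit of > 10000 nM in this assay, at which 1 of the 3 values shown sits. Compound 4 `COc1cccc(C(Nc2ccc(C)cc2Cl)C(=O)CCc2ccncc2)c1` differs from compound 3 in one place: methoxy in place of methyl on an aromatic carbon. For the measured compounds named here, no measured step changes methyl to methoxy. Going by the values given here, the only single-place step, an at least 3.0-fold higher number from compound 2 to compound 3 (0.48 log units; beyond the scatter), ended at the limit for compound 3, so it gives no firm starting point and no direction for this swap. A step that the limit leaves unreadable from compound 3 to compound 4 is expected, with a real chance that again only a limit is reported. Compound 4 is expected to give about 12000 nM in this assay, within a range from 3000 nM to 50000 nM.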

Compound 4, inhibition constant: > 10000 nM
Compound 4 was reported as a limit; the forecaster's own chance of this, stated with the estimate: 65%; the middle value lies beyond the limit too.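

In this assay compound 4 is reported only as a limit, as compound 3 is, so the step between them cannot be read and methoxy cannot be ranked against methyl at this place. The readable change is an at least 3.0-fold higher number from compound 2 to compound 4 (0.48 log units; beyond the scatter) and so 3-methoxyphenyl, like 3-methylphenyl, gives only a limit where 2-isopropylphenyl gives a number. Both groups at this place therefore end at the same ceiling: the limit of > 10000 nM in this assay, at which 2 of the 4 values shown sit.

As far as these compounds go, whether another group on this ring carbon, such as an amine or a carboxylic acid, would give a number stays open. So does how far past the limit compound 3 and compound 4 really lie.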